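Anilide substituent changes in one agonist series

A few compounds are considered here, and "the series" means these few. Any claim that something is new, unique, unknown or untested is made for them only; others in the source may bear on it.

Compound 1 `CCc1cccc(NC(=O)CN2CCC(c3cccc[n+]3[O-])CC2)c1`: 95 nM
Compound 2 `Cc1cccc(NC(=O)CN2CCC(c3cccc(O)c3)CC2)c1`: 8 nM
Compound 3 `O=C(CN1CCC(c2cccc[n+]2[O-])CC1)Nc1cccc(-c2ccccc2)c1`: 360 nM

In a functional assay on HEK293 cells for agonist activity at D(4) dopamine receptor (Homo sapiens), read by FLIPR (on this read-out higher numbers stand for an effect only at larger amounts of compound and lower numbers for an effect already at smaller amounts), compound 3 gives 360 nM, the highest number of the three. Compound 1 gives 95 nM, and compound 2, which differs from the other two in both aryl groups, gives 8 nM.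

Compound 4 `O=C(CN1CCC(c2cccc[n+]2[O-])CC1)Nc1cccc(OC(F)(F)F)c1` has not been measured. It differs from compound 3 by trifluoromethoxy in place of phenyl on an aromatic carbon. For the measured compounds named here, the only measured step at this position is a 3.8-fold higher number from compound 1 to compound 3 (0.58 log units; beyond the scatter), where phenyl entered in place of ethyl. Taking the phenyl out again for a smaller group is expected to give back part of that step, with the direction of the change in this assay downward. Compound 4 is therefore estimated at 150 nM, range 50 nM to 500 nM. The expected step is a 2.4-fold lower number from compound 3 to compound 4 (0.38 log units; beyond the scatter).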

Compound 4, half-maximal effective concentration: 135 nM
Compound 4: the middle estimate sits 1.1-fold (0.05 log units) above what was measured, and the stated range covers the measured number.
By their numbers in this assay, from the lowest: compound 2; then compounds 1 and 4 (each within the scatter of the next); then compound 3.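

In this assay trifluoromethoxy in place of phenyl gives a 2.7-fold lower number from compound 3 to compound 4 (0.43 log units; beyond the scatter) and so shows that the higher number of compound 3 does not follow from every replacement of ethyl at this position. Trifluoromethoxy in place of ethyl gives a 1.4-fold higher number from compound 1 to compound 4 (0.15 log units; within the scatter) and so does not separate these two groups, despite their different atoms. From the compounds shown here alone, whether an amine, a carboxylic acid or a longer alkoxy chain at this position would stay with them or move towards phenyl remains open. Also open, going by these compounds, is whether these steps carry over to the core of compound 2. No measurement at hand explains either step.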